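Swapping Sulfanylethyl for Hydroxymethyl in Compound 3

The source may report more compounds than this note shows. Statements on the series, on what has been measured and on what is new or still open speak of the compounds shown alone.

Compound 1, `N=C(CS)NCC12CCC(C(=O)O)(CC1)CC2`: 0%
Compound 2, `CC(S)C(=N)NCC(C)(C)C`: 0%

Both compounds were tested in a functional assay on the whole organism (stomach, strain beagle) for inhibition, with Canis familiaris (Canis lupus familiaris) as the target, with a stated time of 2 h, at a dose of 8 mg/kg; on this read-out lower numbers stand for a weaker effect and higher numbers for a stronger effect at the one dose given. Compound 2 stands level with compound 1 at the digits shown, the two lying within the usual scatter of each other, so neither shows any measurable effect in this assay. Compound 3, `CC(C)(C)CNC(=N)CO`, differs from compound 2 in one place: hydroxymethyl in place of 1-sulfanylethyl on a carbon with a double bond to nitrogen.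

No step between two measured compounds has been shown, so there is no measured move to lean on. Because compound 2 gives 0% in this assay, and because compound 1 gives 0% with a different shape altogether, the step of no change at the digits printed from compound 2 to compound 3 (within the scatter) is expected to be none beyond the scatter. Compound 3 is therefore estimated to give 0% in this assay, with a range from 0% to 10%.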

Compound 3, a percentage reported as inhibition, in the whole organism at one dose (the size of the read-out at that dose, not a potency): 22%
For compound 3 the middle estimate is 22 percentage points below the measured one; measured number outside the range, above it.
By their numbers in this assay, from the lowest: compounds 1 and 2 (each within the scatter of the next); then compound 3.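

In this assay, among the compounds shown here, replacing the 1-sulfanylethyl group with a hydroxymethyl group gives a number 22 percentage points higher from compound 2 to compound 3 (beyond the scatter), the first change in the read-out in this small set. This position is therefore not silent, and with the rest of the molecule unchanged, a measurable effect here does not need the sulfur of compound 2. No measurement shown explains the rise.

The swap removes a carbon and exchanges sulfur for oxygen at once, so the compounds shown cannot say which of these matters; sulfanylmethyl and 1-hydroxyethyl at this position would pull the two apart. As far as these compounds go, whether an aminomethyl group or a longer chain ending in a hydroxyl group would go further in the same direction also remains open.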